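Amide acyl variation in a chemokine receptor binding series

The source may report more compounds than this note shows. Statements on the series, on what has been measured and on what is new or still open speak of the compounds shown alone.

Compound 1 `CC(C)CCC(=O)N[C@@H](C(=O)N1CCC(c2ccc(Cl)cc2)CC1)C(C)C` gives 26 nM in an assay on THP-1 cells for displacement of a labelled ligand from C-C chemokine receptor type 1 (Homo sapiens); a lower number here means a stronger inhibitor, a higher number a weaker inhibitor. Compound 2 `Cc1ccc(C(=O)N[C@@H](C(=O)N2CCC(c3ccc(Cl)cc3)CC2)C(C)C)cc1` gives 25 nM in this assay, and compound 3 `Cc1ccccc1C(=O)N[C@@H](C(=O)N1CCC(c2ccc(Cl)cc2)CC1)C(C)C` gives 32 nM in this assay. Compound 3 carries the highest of the three numbers, yet a 1.2-fold higher number from compound 1 to compound 3 (0.09 log units; within the scatter) and a 1.3-fold higher number from compound 2 to compound 3 (0.11 log units; within the scatter) both stay within the scatter, as does a 1.0-fold lower number from compound 1 to compound 2 (0.02 log units; within the scatter). Compound 4 `CC(C)[C@@H](NC(=O)CCCc1ccccc1)C(=O)N1CCC(c2ccc(Cl)cc2)CC1` differs from compound 3 by 3-phenylpropyl in place of 2-methylphenyl on a carbonyl carbon. For the measured compounds named here, the steps that bear on this change are the exchange of a chain for an aryl group, a 1.2-fold higher number from compound 1 to compound 3 (0.09 log units; within the scatter), and of one aryl group for another, a 1.3-fold higher number from compound 2 to compound 3 (0.11 log units; within the scatter); neither moved the number beyond the scatter, so for compound 4 no step beyond the scatter is expected in this assay. Compound 4 is therefore estimated at 28 nM, within 12 nM to 65 nM, an expected step of a 1.1-fold lower number from compound 3 to compound 4 (0.06 log units; within the scatter).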

Compound 4, half-maximal inhibitory concentration: 95 nM
Beside the measured number, compound 4's estimate is 3.4-fold (0.53 log units) below it; the whole stated range lies below it.
By their numbers in this assay, from the lowest: compounds 2, 1 and 3 (each within the scatter of the next); then compound 4.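

For the compounds shown here, the position on the carbonyl carbon is not indifferent in this assay: 3-phenylpropyl gives the first steps beyond the scatter, (a 3.0-fold higher number from compound 3 to compound 4 (0.47 log units; beyond the scatter)) against 2-methylphenyl and (a 3.8-fold higher number from compound 2 to compound 4 (0.58 log units; beyond the scatter)) against 4-methylphenyl. Adding a phenyl ring to the end of the chain has a similar modest result, with benzyl in place of isopropyl (a 3.7-fold higher number from compound 1 to compound 4 (0.56 log units; beyond the scatter)). Nothing available gives a reason for this rise. The compounds shown leave open how the number changes with 2-phenylethyl, with a longer chain ending in phenyl, or with an amine at the end of the chain.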